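The source may report more compounds than this note shows. Statements on the series, on what has been measured and on what is new or still open speak of the compounds shown alone.

Measured so far:
compound 1 `CC(=O)NS(=O)(=O)c1ccc(N/C(S)=N\c2ccnc3cc(C(F)(F)F)ccc23)cc1` with 30000 nM;
compound 2 `O=S(=O)(Nc1ccccn1)c1ccc(N/C(S)=N\c2ccnc3cc(C(F)(F)F)ccc23)cc1` with 87500 nM;
compound 3 `Cc1cc(C)nc(NS(=O)(=O)c2ccc(N/C(S)=N\c3ccnc4cc(C(F)(F)F)ccc34)cc2)n1` with 40200 nM.

All three were tested in a functional assay on LoVo cells (Homo sapiens) for antiproliferative activity, read by sulforhodamine B assay, with a stated time of 48 h; on this read-out higher numbers stand for weaker inhibition and lower numbers for stronger inhibition. Compound 1 gives the lowest number of the three; compound 3 sits within the scatter of it, while compound 2 is modestly higher: a 2.9-fold higher number from compound 1 to compound 2 (0.46 log units; beyond the scatter).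

Compound 4 `COc1cc(NS(=O)(=O)c2ccc(N/C(S)=N\c3ccnc4cc(C(F)(F)F)ccc34)cc2)nc(OC)n1` is not yet measured. It differs from compound 1 by 2,6-dimethoxypyrimidin-4-yl in place of acetyl on a sulfonamide nitrogen. Two measured steps start from the same acetyl group and swap it for a heteroaromatic ring: a 2.9-fold higher number from compound 1 to compound 2 (0.46 log units; beyond the scatter) and a 1.3-fold higher number from compound 1 to compound 3 (0.13 log units; within the scatter). Neither swap lowered the number; one left it within the scatter and one raised it modestly. A heteroaromatic ring in place of acetyl is therefore expected to leave the number near that of compound 1 or raise it modestly, as in a 1.5-fold higher number from compound 1 to compound 4 (0.18 log units; within the scatter). Compound 4 is estimated at 45000 nM, with a range of 20000 nM to 110000 nM.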

Compound 4, half-maximal inhibitory concentration: 76700 nM
Compound 4: middle estimate off by 1.7-fold (0.23 log units), on the low side; low and high end bracket the measured number.
By their numbers in this assay, from the lowest: compounds 1, 3, 4 and 2 (each within the scatter of the next, the first and the last beyond it).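

Replacing acetyl with 2,6-dimethoxypyrimidin-4-yl gives a 2.6-fold higher number from compound 1 to compound 4 (0.41 log units; beyond the scatter) and shows that a third ring on the sulfonamide nitrogen also fails to lower the number. Compound 4 cannot be separated from either of the other ring compounds, with a 1.9-fold higher number from compound 3 to compound 4 (0.28 log units; within the scatter) and a 1.1-fold lower number from compound 2 to compound 4 (0.06 log units; within the scatter) both within the scatter. Nothing available explains these differences. From the compounds shown here alone, it remains open whether a longer acyl chain or a small alkyl group such as methyl on this nitrogen would bring the number below that of compound 1.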